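The source may hold more compounds than are shown below. What is called first, only, known or untested is meant among the compounds shown, and "the series" means these compounds.

Measured compounds:
Compound 2, `O=C(CCC1=CCCN(CCCc2ccc(-c3ccccc3)cc2)C1=O)NO`: 1040 nM
Compound 3, `O=C(CCC1=CCCN(CCCCc2cccc3ccccc23)C1=O)NO`: 1470 nM
Compound 1, `CC(=O)Nc1ccc(CN2CCC=C(CCC(=O)NO)C2=O)cc1`: "not determined" (no result reported)

Compounds 2 and 3 were tested in a functional assay on MDA-MB-231 cells (Homo sapiens) for inhibition, read by sulforhodamine B assay; on this read-out higher numbers stand for weaker inhibition of growth and lower numbers for stronger inhibition of growth. Compound 2 gives 1040 nM in this assay, and compound 3 gives 1470 nM there. The two values lie within the usual scatter of each other, so nothing separates them. Compound 1 shares the hydroxamic acid and the core of the other two but carries a benzyl group bearing acetamido; for compound 1 no number is available in this assay.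

Compound 4, `Cc1ccc(CN2CCC=C(CCC(=O)NO)C2=O)cc1`, has not yet been measured. It differs from compound 1 in one place: methyl in place of acetamido on an aromatic carbon. Among the measured compounds shown here, because no value exists for compound 1, no step between the two can be stated, and the size of the change in this assay can only be guessed. The expectation rests solely on compounds 2 and 3. Compound 4 is expected to give about 2000 nM in this assay, with a likely range from 600 nM to 8000 nM.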

Compound 4, concentration for 50% growth inhibition: 1430 nM
Compound 4: middle estimate off by 1.4-fold (0.15 log units), on the high side; low and high end bracket the measured number.
By their numbers in this assay, from the lowest: compounds 2, 4 and 3 (each within the scatter of the next).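

Among the compounds shown here, compound 1 has no single number in this assay here, so no step from it to compound 4 can be read. No evidence at hand bears on the value of compound 4. On these data alone, what exchanging acetamido for methyl does to growth inhibition remains open.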